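The source may hold more compounds than are shown below. What is called first, only, known or untested is meant among the compounds shown, and "the series" means these compounds.

Compound 1 `CCOc1ccc(-c2cccc(C)c2)cc1`: 54%
Compound 2 `CCOc1ccc(-c2cccc(C(=O)NC)c2)cc1`: 40%

In an assay on COS-7 cells for inhibition of patatin-like phospholipase domain-containing protein 2 (Mus musculus), tested at 200 uM (a higher number here means more inhibition at the concentration tested (going by the name of the read-out), a lower number less inhibition), compound 1 gives 54%, and compound 2 gives 40%, the lower of the two numbers measured. For the measured compounds named here, the single measured step, a number 14 percentage points lower from compound 1 to compound 2 (beyond the scatter), concerns the methylcarbamoyl group that the next change removes. Compound 3 `CCOc1ccc(-c2cccc([N+](=O)[O-])c2)cc1` differs from compound 2 by nitro in place of methylcarbamoyl on an aromatic carbon. Going by the values given here, no measured step shows what a nitro group does here, so the direction is uncertain; a modest rise is estimated, a number 6 percentage points higher from compound 2 to compound 3 (within the scatter). Compound 3 is therefore expected to give 46%, in a range from 25% to 66%.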

Compound 3, a percentage reported as inhibition, at one concentration (the size of the read-out at that concentration, not a potency): 35%
Compound 3: middle estimate off by 11 percentage points, on the high side, and the stated range covers the measured number.
By their numbers in this assay, from the lowest: compounds 3 and 2 (each within the scatter of the next); then compound 1.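

In this assay, nitro in place of methylcarbamoyl gives a number 5 percentage points lower from compound 2 to compound 3 (within the scatter) and so cannot be told apart from it, although the two groups differ in hydrogen-bond donors. Nitro in place of methyl gives a number 19 percentage points lower from compound 1 to compound 3 (beyond the scatter) and thus joins methylcarbamoyl as a second group that falls short of methyl at this position. No evidence on the cause of these differences is available. The compounds shown leave open whether this shortfall is specific to these two groups. An amine, a carboxylic acid or a longer carbon chain at this position could match methyl or exceed it.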